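Adding a Second Carbonyl Group to Compound 1

The source may report more compounds than this note shows. Statements on the series, on what has been measured and on what is new or still open speak of the compounds shown alone.

Compound 1 `CC(C)=CCC/C(C)=C/CC/C(C)=C/C(=O)NC(=N)N` was tested in a functional assay on MCF7 cells (Homo sapiens) for inhibition, read by MTT assay, with a stated time of 72 h (a higher number here means a weaker inhibitor of growth, a lower number a stronger inhibitor of growth), where compound 1 gives 22000 nM. Compound 2 `CC(C)=CC(=O)NC(=N)N` returns only a limit of the assay in this assay, namely > 100000 nM. Compound 3 `C=C1CCCC(C)(C)[C@@H]1CC/C(C)=C/C(=O)NC(=N)NC(=O)C=C(C)C` gives 28100 nM in this assay. The numbers of compound 1 and compound 3 cannot be told apart, as the gap between them lies within the scatter. Compound 4 `CC(C)=CCC/C(C)=C/CC/C(C)=C/C(=O)NC(=N)NC(=O)C=C(C)C` differs from compound 1 by (2-methylprop-1-en-1-yl)carbonyl in place of hydrogen on an amine nitrogen. Because compound 3 gives 28100 nM while also bearing the (2-methylprop-1-en-1-yl)carbonyl group, the same change is expected to move compound 1 little. The expected step is a 1.2-fold higher number from compound 1 to compound 4 (0.07 log units; within the scatter), within the scatter. Compound 4 is estimated at 26000 nM, with a range from 10000 nM to 65000 nM.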

Compound 4, concentration for 50% growth inhibition: 23400 nM
Compound 4: the middle estimate sits 1.1-fold (0.05 log units) above what was measured; the measured number falls inside the stated range.
By their numbers in this assay, from the lowest: compounds 1, 4 and 3 (each within the scatter of the next). At a limit, above all of these: compound 2.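

In this assay, for the compounds shown here, this pair gives the first direct reading of the amine nitrogen: a 1.1-fold higher number from compound 1 to compound 4 (0.03 log units; within the scatter), so (2-methylprop-1-en-1-yl)carbonyl can stand in place of hydrogen without a change beyond the scatter. Compound 3 carries the same group, but no compound shown matches it without the group, so only this pair isolates the change. On the core of compound 1, the hydrogen at this nitrogen is therefore not needed to keep this level of growth inhibition.

Going by these compounds, whether an acetyl or benzoyl group on the same nitrogen would behave alike remains open. No measurement shown bears on the reason for so small a step.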